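The source may report more compounds than this note shows. Statements on the series, on what has been measured and on what is new or still open speak of the compounds shown alone.

Measured so far in an ADME assay on MT4 cells (Homo sapiens) for cytotoxicity, read by MTT assay; a higher number here means that more compound is tolerated, a lower number that less compound is tolerated:
- compound 1 `COc1cccc2c1c(C(=O)/C=C(\O)C(=O)O)cn2Cc1ccc(F)cc1`: 41100 nM
- compound 2 `CCOC(=O)/C(O)=C/C(=O)c1cn(Cc2c(F)cccc2F)c2cccc(OC)c12`: 63400 nM

Compound 2 carries the higher of the two numbers in this assay, but the gap to compound 1 is within the scatter, so the two cannot be ordered on what has been measured. Both share the core and differ in two places at once, the fluorine pattern on the benzyl group and the ethoxycarbonyl against the carboxy, so neither difference can be read on its own from these two values.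

Compound 3 `COc1cccc2c1c(C(=O)/C=C(\O)C(=O)O)cn2Cc1c(F)cccc1F` is not yet measured. It differs from compound 2 by one change: hydrogen in place of ethyl on an oxygen next to a carbonyl group. Among the compounds with values here, no measured pair shows the effect of this change by itself, so there is nothing to set a direction by. The step from compound 2 to compound 3 is therefore expected to be a 1.2-fold lower number from compound 2 to compound 3 (0.06 log units; within the scatter), that is, nothing beyond the scatter. Compound 3 is estimated to give about 55000 nM in this assay, with a range from 25000 nM to 120000 nM.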

Compound 3, half-maximal cytotoxic concentration: 44300 nM
Compound 3: the middle estimate sits 1.2-fold (0.09 log units) above what was measured; the measured number falls inside the stated range.
By their numbers in this assay, from the lowest: compounds 1, 3 and 2 (each within the scatter of the next).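

In this assay, within the data shown here, hydrogen in place of ethyl on an oxygen next to a carbonyl group gives a 1.4-fold lower number from compound 2 to compound 3 (0.16 log units; within the scatter), so the ethoxycarbonyl to carboxy change, read alone for the first time, produces no difference that can be told from the scatter. 2,6-Difluorophenyl in place of 4-fluorophenyl on a saturated chain carbon bound to an aromatic nitrogen gives a 1.1-fold higher number from compound 1 to compound 3 (0.03 log units; within the scatter), so the two differences combined in compound 1 and compound 2 are now separated, and neither step alone stands beyond the scatter. Nothing is available that would explain these results.

Still open, as far as these compounds go, is whether a longer chain or a benzyl group in place of the ethyl on that oxygen, or an amine in place of that oxygen, would shift the number in this assay beyond the scatter. Also open, from the compounds shown here alone, is whether an unsubstituted phenyl or a 4-chlorophenyl on the saturated chain carbon would read differently from the two fluorinated phenyl groups.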